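The source may report more compounds than this note shows. Statements on the series, on what has been measured and on what is new or still open speak of the compounds shown alone.

Compound 2, drawn as `C=CC1=C(C(=O)NC2CCCCC2)C(c2ccc(OC)cc2)OC1`, is the starting point of this account. In a functional assay on A549 cells (Homo sapiens) for cytotoxicity, read by MTT assay, with a stated time of 24 h (on this read-out lower numbers stand for stronger inhibition and higher numbers for weaker inhibition), compound 2 reaches only a limit of the assay, > 100000 nM. The same holds for its two measured neighbours. Compound 1, drawn as `C=CC1=C(C(=O)O)C(c2ccc(OC)cc2)OC1`, also stops at a limit in this assay, > 100000 nM. Compound 3, drawn as `C=CC1=C(C(=O)NC2CCCCC2)C(c2ccc(F)cc2)OC1`, likewise gives a limit in this assay, > 100000 nM. The step from compound 1 to compound 2 is therefore a step that the two limits leave unreadable from compound 1 to compound 2, and the step from compound 2 to compound 3 is a step that the two limits leave unreadable from compound 2 to compound 3. All that the measured data offer is the limit of > 100000 nM in this assay, at which 3 of the 3 values shown sit, so no change in this assay has yet been resolved in either direction.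

The next compound, compound 4, drawn as `C=CC1=C(C(=O)NCc2ccc(C)cc2)C(c2ccc(OC)cc2)OC1`, differs from compound 2 by 4-methylbenzyl in place of cyclohexyl on an amide-type nitrogen. Neither measured step bears on this change with a readable size, since both sit at the limit. With every measured compound at the limit, the step from compound 2 to compound 4 is expected to be a step that the limit leaves unreadable from compound 2 to compound 4, meaning no resolvable movement. Compound 4 is accordingly expected to give about 150000 nM in this assay, within a range from 30000 nM to 1000000 nM, most likely reported again as a limit.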

Compound 4, half-maximal inhibitory concentration: > 100000 nM
Compound 4 was reported as a limit (the forecaster's own chance of this, stated with the estimate: 75%); the middle value does not contradict the limit.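

Compound 4, like compound 2, gives only a limit in this assay and so the exchange of cyclohexyl for 4-methylbenzyl yields no readable step between the two compounds. The compounds shown leave open whether any change on the shared core can move this read-out at all: the limit of > 100000 nM in this assay, at which 4 of the 4 values shown sit.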